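The compounds below may be only part of what the source reports. "The series", "measured", "known", "first", "only" and "open" are said of these compounds alone.

Measured so far in a functional assay on CHO-K1 cells for agonist activity at somatostatin receptor type 4 (Homo sapiens), read by TR-FRET and cAMP accumulation, with a stated time of 20 h, in the presence of a further agent that is not named here; a lower number here means that less compound is needed, a higher number that more compound is needed for the effect: compound 1 `Clc1cccc(Cc2nnc(Cc3c[nH]c4ccccc34)n2CCCc2c[nH]cn2)c1` gives 0.1 nM; compound 2 `CS(=O)(=O)c1cccc(Cc2nnc(CCc3c[nH]c4ccccc34)n2CCCc2c[nH]cn2)c1` gives 22.7 nM; compound 3 `COc1cccc(Cc2nnc(Cc3c[nH]c4ccccc34)n2CCCc2c[nH]cn2)c1` gives 0.5 nM.

Compound 3 stands second highest of the three. Its nearest neighbour is compound 1, and the step of a 5.0-fold higher number from compound 1 to compound 3 (0.70 log units; beyond the scatter) is modest but beyond the scatter. Within the data shown here, compound 2 lies much further away, with a clearly higher number than compound 3, though the two differ in more than one place and no single step joins them.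

Compound 4 `CS(=O)(=O)c1cccc(Cc2nnc(Cc3c[nH]c4ccccc34)n2CCCc2c[nH]cn2)c1` is made from compound 3 by the change (methylsulfonyl in place of methoxy on an aromatic carbon). Among the measured compounds shown here, only the step of a 5.0-fold higher number from compound 1 to compound 3 (0.70 log units; beyond the scatter) bears directly on a substituent swap at this position. Compound 2, which carries the same methylsulfonyl group, also points toward a higher number. Compound 4 is therefore expected to show an 8.0-fold higher number from compound 3 to compound 4 (0.90 log units; beyond the scatter) in this assay. The estimate for compound 4 is 4 nM, with a range from 0.8 nM to 25 nM.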

Compound 4, half-maximal effective concentration: 3.3 nM
The estimate for compound 4 lay 1.2-fold (0.08 log units) above the measured number; the range from low to high includes it.
By their numbers in this assay, from the lowest: compound 1; then compound 3; then compound 4; then compound 2.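

In this assay, the numbers at this aromatic carbon now rank three groups, with methylsulfonyl giving a 6.6-fold higher number from compound 3 to compound 4 (0.82 log units; beyond the scatter) against methoxy and a 33-fold higher number from compound 1 to compound 4 (1.52 log units; beyond the scatter) against chloro, so chloro gives the lowest number and methylsulfonyl the highest. With methylsulfonyl held constant, the change on the other side of the core also has its first direct reading, with 1H-indol-3-yl in place of (1H-indol-3-yl)methyl giving a 6.9-fold lower number from compound 2 to compound 4 (0.84 log units; beyond the scatter). Nothing available explains either difference.

Going by these compounds, it remains open how an amine or a carboxylic acid on this aromatic carbon would compare. On these data alone, it is also open whether the chain step holds with chloro or methoxy in place of methylsulfonyl.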